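Replacing the 4-carboxyphenyl group of compound 2

The compounds below may be only part of what the source reports. "The series", "measured", "known", "first", "only" and "open" are said of these compounds alone.

Compound 1 `Cc1nc2ccc(Cl)cn2c1C(=O)NCc1ccc(-c2ccccc2)cc1`: > 2 h
Compound 2 `CCc1nc2cc(Cl)ccn2c1C(=O)NCc1ccc(-c2ccc(C(=O)O)cc2)cc1`: > 2 h

In an ADME assay (liver) for metabolic stability, with Liver microsome (Homo sapiens) as the target, using microsomes (a higher number here means that the compound lasts longer, a lower number that the compound disappears faster), compound 1 gives > 2 h, which is a limit of the assay and not a number. Compound 2 gives > 2 h, likewise a limit and not a number. Compound 2 therefore has no exact position, and neither measured compound can be ranked against the other: the limit of > 2 h in this assay, at which 2 of the 2 values shown sit.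

Compound 3 `CCc1nc2cc(Cl)ccn2c1C(=O)NCc1ccc(N2CCC(Cl)CC2)cc1` has not yet been measured. The change is 4-chloropiperidin-1-yl in place of 4-carboxyphenyl on an aromatic carbon, para to a large group. Among the measured compounds shown here, no measured step covers this replacement, and neither compound 1 nor compound 2 carries a non-aromatic ring in that place. The prediction therefore has little support, and a wide range is appropriate. A moderate downward step in this assay is expected, although another result reported only as a limit remains quite possible. The expected change is an at least 1.3-fold lower number from compound 2 to compound 3 (0.12 log units; that floor lies within the scatter). For compound 3 the estimated half-life is 1.5 h, with an expected range of 0.5 h to 3 h.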

Compound 3, half-life: 0.183 h
Beside the measured number, compound 3's estimate is 8.2-fold (0.91 log units) above it; measured number outside the range, below it.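

In this assay the change to 4-chloropiperidin-1-yl gives an at least 10-fold lower number from compound 2 to compound 3 (1.03 log units; beyond the scatter), so the read-out is clearly sensitive to what this place carries, on an aromatic carbon and para to a large group. The step is a floor and not a full size, because compound 2 sits at a limit of the assay, while compound 3 alone among the compounds shown has a number: the limit of > 2 h in this assay, at which 2 of the 3 values shown sit. Compound 3 is also the only compound shown with a non-aromatic ring in this place, and it gives the series its first reading below the limit.

The step removes the carboxylic acid and the aromatic ring and brings in the non-aromatic ring and the chlorine all at once, and it does not separate the contribution of any one of these. Still open, as far as these compounds go, is whether an unsubstituted piperidine or a morpholine ring in this place would stay at the limit or drop as far as the 4-chloropiperidin-1-yl group does.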